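The source may report more compounds than this note shows. Statements on the series, on what has been measured and on what is new or still open speak of the compounds shown alone.

Working notes on the series.

Compound 1 `Cc1ccc(-n2cc(C(=O)Nc3cc(F)cc(F)c3)c(=O)c3ccc(N(C)C)nc32)cc1OCCCCCCC[N+]12CCN(CC1)CC2` gives 9.71% in an assay on LX2 cells for inhibition of COL1A1 promoter (Homo sapiens), read by a luciferase reporter, with a stated time of 24 h, tested at 50 uM; a higher number here means a stronger effect of the compound at the concentration tested, a lower number a weaker effect. Compound 2 `CN(C)c1ccc2c(=O)c(C(=O)Nc3cc(F)cc(F)c3)cn(-c3ccc(Cl)c(OCCCCCCC[N+]45CCN(CC4)CC5)c3)c2n1` gives 18.7% in this assay. The difference between these two structures is chloro in place of methyl on an aromatic carbon, and the measured step is a number 9 percentage points higher from compound 1 to compound 2 (within the scatter). Compound 3 `Cc1cc(-n2cc(C(=O)Nc3cc(F)cc(F)c3)c(=O)c3ccc(N(C)C)nc32)ccc1OCCCCCCC[N+]1(C)CCN(C)CC1` gives 32% in this assay; this is the highest number of the three, and its gaps to compound 2 and to compound 1 both lie beyond the scatter. How the core of compound 3 differs from the core of compound 1 is not broken down here.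

Compound 4 `CN1CC[N+](C)(CCCCCCCOc2ccc(-n3cc(C(=O)Nc4cc(F)cc(F)c4)c(=O)c4ccc(N(C)C)nc43)cc2Cl)CC1` has not yet been measured in this assay. It differs from compound 3 by chloro in place of methyl on an aromatic carbon. This is the same kind of change as that between compound 1 and compound 2, but the place is not identical: in the earlier pair the aromatic carbon is ortho to a large group and para to a large group, whereas here it is ortho to a large group and meta to a large group. Because the earlier step of a number 9 percentage points higher from compound 1 to compound 2 (within the scatter) stayed within the scatter, a comparably small step is expected here, a number 6 percentage points higher from compound 3 to compound 4 (within the scatter). Compound 4 is accordingly estimated at 38%, with a likely range from 22% to 54%.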

Compound 4, a percentage reported as inhibition, at one concentration (the size of the read-out at that concentration, not a potency): 15.4%
Compound 4: middle estimate off by 22.6 percentage points, on the high side; measured number outside the range, below it.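

In this assay, chloro in place of methyl on an aromatic carbon gives a number 16.6 percentage points lower from compound 3 to compound 4 (beyond the scatter) and so cannot be treated as a fixed step on any core in this series. Set beside the earlier pair, the two steps differ: the same change on two cores in this assay, a number 9 percentage points higher (within the scatter) from compound 1 to compound 2 and a number 16.6 percentage points lower (beyond the scatter) from compound 3 to compound 4, 25.6 percentage points apart, beyond the scatter of two such steps. This shows that the size and direction of the step seen on the core of compound 1 did not carry over to the core of compound 3, but it does not show what sets them apart, as the two pairs differ both in core and in the place of the change on the aromatic ring, and two pairs give no general rule.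

The compounds shown leave open whether the same change in one identical place would behave alike on both cores. They also leave open how a fluoro or a methoxy in place of the methyl, or a shorter or longer chain, would read in this assay on either core.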